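The source may hold more compounds than are shown below. What is called first, only, known or untested is meant among the compounds shown, and "the series" means these compounds.

Measured compounds:
compound 1 `CCCNNC(=O)c1cnc(N2CCN(Cc3c[nH]c4ccccc34)CC2)nc1` — > 20000 nM
compound 2 `CCCCCCNNC(=O)c1cccc(NCc2ccccc2)c1` — > 20000 nM

In an assay on isolated protein for inhibition of protein deacetylase HDAC6 (Homo sapiens) (on this read-out higher numbers stand for weaker inhibition and lower numbers for stronger inhibition), compound 1 gives > 20000 nM; this is a limit of the assay and not a number. Compound 2 gives > 20000 nM in this assay, again a limit rather than a number. Compound 1 therefore stands at the limit of > 20000 nM in this assay, at which 2 of the 2 values shown sit, so nothing shown places it anywhere but at the limit, and no ordering between compound 1 and compound 2 can be read from the values.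

Compound 3 `CCCCCCNNC(=O)c1cnc(N2CCN(Cc3c[nH]c4ccccc34)CC2)nc1` has not yet been measured in this assay. It differs from compound 1 by propyl in place of hydrogen on a saturated chain carbon, three bonds along the chain from an amine nitrogen. Among the measured compounds shown here, no step between measured compounds is available to size this change. What is known is that compound 2, which carries the longer chain of the same kind, sits at the limit. The step is therefore expected to stay within the scatter, with no direction beyond it.

For compound 3 the estimate in this assay is 30000 nM, ranging from 10000 nM to 100000 nM. The implied step that the limit leaves unreadable from compound 1 to compound 3 is expected to remain inside the scatter, most likely again as a limit.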

Compound 3, half-maximal inhibitory concentration: > 20000 nM
Compound 3 ended at the assay's limit; the forecaster's own chance of this, stated with the estimate: 85%; the middle value lies beyond the limit too.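

In this assay compound 3 gives > 20000 nM, a limit of the assay and not a number. Among the compounds shown here, no step from compound 1 to compound 3 can be read from this result. The compounds shown leave open whether any chain or core in this series gives a readable value in this assay, and whether chain length matters there at all.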